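Aryl amide series: chain terminus swap in an acyltransferase assay

The source may report more compounds than this note shows. Statements on the series, on what has been measured and on what is new or still open speak of the compounds shown alone.

Measured so far:
compound 1 `CCCCCCCCCCCCCCCC(=O)Nc1cccc2c1OC(C)(C)C2` — 890 nM
compound 2 `CCCCCCCCCCCCC(C)(C)C(=O)Nc1c(C)cc(C)c2c1OC(C)(C)C2` — 33 nM

In an assay for inhibition of acyl-CoA:cholesterol acyltransferase (Oryctolagus cuniculus), using microsomes (on this read-out lower numbers stand for stronger inhibition and higher numbers for weaker inhibition), compound 1 gives 890 nM, and compound 2 gives 33 nM, the lowest of the two numbers; its nearest neighbour, compound 1, lies beyond the scatter. Among the compounds with values here, no single-change step between measured compounds is available, so compound 2 is the only anchor for compound 3 `Cc1cc(C)c(NC(=O)C(C)(C)CCCCCc2ccccc2)c2c1CC(C)(C)O2`.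

Compound 3 differs from compound 2 by phenyl in place of heptyl on a saturated chain carbon, six bonds along the chain from a carbonyl carbon. The amide, the substituted core and the branching at the carbon next to the carbonyl stay as in compound 2. There is nothing in the measured pair that tests this change, so the size of its step in this assay is a guess; a modest weakening seems more likely than none, given how strongly the chain region sets the numbers between compound 1 and compound 2.

The estimated step is a 3.0-fold higher number from compound 2 to compound 3 (0.48 log units; beyond the scatter). For compound 3 the expected value in this assay is 100 nM, within a range from 30 nM to 400 nM.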

Compound 3, half-maximal inhibitory concentration: 120 nM
Beside the measured number, compound 3's estimate is 1.2-fold (0.08 log units) below it; measured number inside the range.
By their numbers in this assay, from the lowest: compound 2; then compound 3; then compound 1.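

In this assay, within the data shown here, phenyl in place of heptyl on a saturated chain carbon, six bonds along the chain from a carbonyl carbon, gives a 3.6-fold higher number from compound 2 to compound 3 (0.56 log units; beyond the scatter) as the only single-change reading. This shows that the chain end affects inhibition in this series, although the step is modest and a terminal phenyl remains compatible with measurable inhibition, with compound 3 at 120 nM in this read-out. No available evidence accounts for the size of this step.

The pair cannot separate the presence of the aromatic ring from the change in chain make-up, since the same difference also reads decyl to 3-phenylpropyl. Still open, on these data alone, is how a cyclohexyl end, a longer chain carrying the phenyl, or a terminal amine or carboxylic acid would compare with heptyl at this position.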